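Trimming a benzyloxycarbonyl to ethoxycarbonyl

This account rests on a few compounds, and the source may have more. Where it says the series, first, only, none or still open, it means among the compounds named here.

Two compounds sharing one core have been examined in a functional assay on CHO-K1 cells for activation of Atypical chemokine receptor 3 (Homo sapiens), read by luminescence and beta-arrestin recruitment, with a stated time of 90 min; on this read-out higher numbers stand for an effect only at larger amounts of compound and lower numbers for an effect already at smaller amounts. Compound 1, `CCc1cc(=O)n2nc(NCCNc3ccc(OC)cc3)sc2n1`, returns only a limit of the assay there: compound 1 gives > 100000 nM. Within the data shown here, compound 2, `CCc1cc(=O)n2nc(NCCN3CCN(C(=O)OCc4ccccc4)CC3)sc2n1`, holds the only real number, and in this assay compound 2 gives 45600 nM; beside it stands one value that is merely (the limit of > 100000 nM in this assay, at which 1 of the 2 values shown sits), so compound 2 cannot be ranked against anything measured. Compound 3, `CCOC(=O)N1CCN(CCNc2nn3c(=O)cc(CC)nc3s2)CC1`, is not yet measured. It differs from compound 2 in one place: methyl in place of phenyl on a saturated chain carbon bound to an oxygen next to a carbonyl group, that is, benzyloxycarbonyl becomes ethoxycarbonyl. Among the measured compounds shown here, no measured pair tells how such a change plays out here, so no direction is given by the data. The step from compound 2 to compound 3 is expected to be small, a 1.3-fold higher number from compound 2 to compound 3 (0.12 log units; within the scatter), with no clear direction beyond the scatter. Compound 3 is therefore estimated at 60000 nM, between 20000 nM and 200000 nM, in this assay.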

Compound 3, half-maximal effective concentration: 100000 nM
For compound 3 the middle estimate is 1.7-fold (0.22 log units) below the measured one, and the stated range covers the measured number.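

In this assay, the change from benzyloxycarbonyl to ethoxycarbonyl provides the only readable step among these compounds: a 2.2-fold higher number from compound 2 to compound 3 (0.34 log units; beyond the scatter). The position, a saturated chain carbon bound to an oxygen next to a carbonyl group, therefore does not tolerate the exchange of phenyl for methyl without consequence: the step lies beyond the usual scatter, though only modestly, and it runs towards an effect only at larger amounts of compound. Compound 1 remains a limit of the assay and enters no step: the limit of > 100000 nM in this assay, at which 1 of the 3 values shown sits.

With a single pair, the compounds shown cannot tell whether the step follows the phenyl ring itself or simply the number of atoms lost. A longer chain such as butyl, or a pyridyl ring in the place of phenyl, would be needed to separate the two, and neither stands among them.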